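Notes on a glucokinase regulatory protein series

The source may hold more compounds than are shown below. What is called first, only, known or untested is meant among the compounds shown, and "the series" means these compounds.

Measured so far in an assay on cells (Hepatocyte) for inhibition of glucokinase regulatory protein (Mus musculus), with stated times of 20 min and 40 min; on this read-out higher numbers stand for an effect only at larger amounts of compound and lower numbers for an effect already at smaller amounts:
compound 1 `CC#C[C@H]1CN(S(=O)(=O)c2ccc(N)nc2)CCN1c1ccc([C@@](O)(CO)C(F)(F)F)cc1` gives 89 nM
compound 2 `CC#C[C@H]1CN(S(=O)(=O)c2ccc(N)nc2)CCN1c1ccc(C(O)(COC)C(F)(F)F)cc1` gives 202 nM
compound 3 `CC#C[C@H]1CN(S(=O)(=O)c2ccc(N)nc2)CCN1c1ccc(S(=N)(=O)C2CC2)cc1` gives 208 nM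

Compound 3 stands at the highest of the three numbers. Its nearest neighbour is compound 2, where a 1.0-fold higher number from compound 2 to compound 3 (0.01 log units; within the scatter) lies within the scatter, so no order between compound 2 and compound 3 can be read. The distance to compound 1 is larger: a 2.3-fold higher number from compound 1 to compound 3 (0.37 log units; beyond the scatter) is beyond the scatter.

Compound 4 `CC#C[C@H]1CN(S(=O)(=O)c2ccc(N)nc2)CCN1c1ccc([C@](O)(CO)C(F)(F)F)cc1` differs from compound 3 at one place: a group of 8 heavy atoms (3 carbon, 2 oxygen, 3 fluorine; no ring) in place of a group of 6 heavy atoms (3 carbon, 1 nitrogen, 1 oxygen, 1 sulfur; one three-membered non-aromatic ring of carbon only), on an aromatic carbon. The group entering carries the same name as the group on compound 1, but with the opposite setting at its defined stereocentre. The measured step that bears on this change is the reverse of a 2.3-fold higher number from compound 1 to compound 3 (0.37 log units; beyond the scatter), which was modest. Going by the values given here, no measured pair shows what the other setting of the stereocentre does, so the step for compound 4 in this assay is expected to be a modest lowering of the number or none beyond the scatter, wide on both sides. The estimate for compound 4 is 150 nM, between 50 nM and 450 nM, which corresponds to an expected step of a 1.4-fold lower number from compound 3 to compound 4 (0.14 log units; within the scatter).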

Compound 4, half-maximal effective concentration: 98 nM
Beside the measured number, compound 4's estimate is 1.5-fold (0.18 log units) above it; measured number inside the range.
By their numbers in this assay, from the lowest: compounds 1 and 4 (each within the scatter of the next); then compounds 2 and 3 (each within the scatter of the next).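

In this assay the setting at the defined stereocentre of the 1,2-dihydroxy-1-(trifluoromethyl)ethyl group, on an aromatic carbon para to a large group, leaves no readable difference, with a 1.1-fold higher number from compound 1 to compound 4 (0.04 log units; within the scatter), and the comparison isolates that single change: the fact that compounds 1 and 4 differ only in the configuration as drawn. The gap first seen with compound 1 therefore holds for the other setting as well: a 2.1-fold lower number from compound 3 to compound 4 (0.33 log units; beyond the scatter) and a 2.1-fold lower number from compound 2 to compound 4 (0.31 log units; beyond the scatter). With both settings now in hand, the separation of this group from the groups on compound 2 and compound 3 does not rest on one particular setting, although compound 2 is itself drawn with no defined setting at the corresponding carbon.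

As far as these compounds go, it remains open whether a carboxylic acid, an amine or a longer chain in place of the 1,2-dihydroxy-1-(trifluoromethyl)ethyl group would keep the number seen for compound 4, and whether the two settings would stay alike with such a group. Also open, from the compounds shown here alone, is what the other stereocentre does, since it is drawn with the same setting on all four compounds.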